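Compound 3 to compound 4 at the carbonyl carbon

A few compounds are considered here, and "the series" means these few. Any claim that something is new, unique, unknown or untested is made for them only; others in the source may bear on it.

Of the compounds shown here, three have been read in an ADME assay on BaF3 cells (Mus musculus) for cytotoxicity, read by CellTiter-Glo and CCK-8 assay, with a stated time of 72 h; on this read-out lower numbers stand for stronger inhibition of growth and higher numbers for weaker inhibition of growth. Compound 1 (`CCC(=O)NCc1ccc(C(=O)Nc2ccc(C)c(Nc3nccc(-c4cccnc4)n3)c2)cc1`) gives > 10000 nM as a limit of the assay. Compound 2 (`CCC(=O)N(CCN(C)C)Cc1ccc(C(=O)Nc2ccc(C)c(Nc3nccc(-c4cccnc4)n3)c2)cc1`) gives > 10000 nM as a limit too. Compound 3 (`Cc1ccc(NC(=O)c2ccc(CN(CCN(C)C)C(=O)C3CC3)cc2)cc1Nc1nccc(-c2cccnc2)n1`) also gives > 10000 nM as a limit and not a number. The whole set sits at one value, namely the limit of > 10000 nM in this assay, at which 3 of the 3 values shown sit, and compound 3 therefore has no number to be placed by.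

Compound 4 (`Cc1ccc(NC(=O)c2ccc(CN(CCN(C)C)C(=O)C(C)C)cc2)cc1Nc1nccc(-c2cccnc2)n1`) differs from compound 3 as follows: isopropyl in place of cyclopropyl on a carbonyl carbon and so carries isopropyl in place of cyclopropyl on a carbonyl carbon. The closest measured change is a step that the two limits leave unreadable from compound 2 to compound 3 at that same carbonyl carbon, with cyclopropyl in place of ethyl. The others, a step that the two limits leave unreadable from compound 1 to compound 2 and a step that the two limits leave unreadable from compound 1 to compound 3 in turn, offer no size either. No step beyond the scatter is therefore expected in this assay for this change. The step expected is a number no higher from compound 3 to compound 4 (the limit leaves the size open) by this estimate. The expected value for compound 4 is 10000 nM within an estimated range of 5000 nM to 20000 nM and a report as a limit is the likely outcome.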

Compound 4, concentration for 50% growth inhibition: > 10000 nM
Compound 4 was reported as a limit; the forecaster's own chance of this, stated with the estimate: 90%; the middle value lies on the limit itself.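

No step can be read among compound 1, compound 2, compound 3 and compound 4 in this assay, where all four are reported as a limit and not as a number: the limit of > 10000 nM in this assay, at which 4 of the 4 values shown sit.

The compounds shown leave open the size of each change, including isopropyl in place of cyclopropyl on the carbonyl carbon.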